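A few compounds are considered here, and "the series" means these few. Any claim that something is new, unique, unknown or untested is made for them only; others in the source may bear on it.

Working notes on a series sharing one core: compound 1 `N#Cc1ccc(-c2nc(-c3ccc4[nH]c(=O)oc4c3)cs2)cc1`, compound 2 `O=c1[nH]c2ccc(-c3csc(-c4ccc(F)c(F)c4)n3)cc2o1` and compound 3 `COc1cc(F)ccc1-c1nc(-c2ccc3[nH]c(=O)oc3c2)cs1`. In an assay on isolated protein for inhibition of protein phosphatase 1D (Homo sapiens), read by malachite green (on this read-out higher numbers stand for weaker inhibition and lower numbers for stronger inhibition), compound 1 gives < 20000 nM, which is a limit of the assay and not a number. In this assay compound 2 gives < 20000 nM, again only a limit. In this assay compound 3 gives < 20000 nM, also a limit rather than a number, so that (the limit of < 20000 nM in this assay, at which 3 of the 3 values shown sit). Compound 3 therefore cannot be placed among the three, as no value here is a number. Compound 4 `NCCOCc1cc(F)ccc1-c1nc(-c2ccc3[nH]c(=O)oc3c2)cs1` differs from compound 3 by (2-aminoethoxy)methyl in place of methoxy on an aromatic carbon. Going by the values given here, no step between measured compounds exists, so no change beyond the usual scatter is expected in either direction. In this assay the expected step is a step that the limit leaves unreadable from compound 3 to compound 4. For compound 4 the estimate in this assay is 5000 nM, with a range from 500 nM to 20000 nM.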

Compound 4, half-maximal inhibitory concentration: < 20000 nM
Compound 4 was reported as a limit; the forecaster's own chance of this, stated with the estimate: 60%; the middle value does not contradict the limit.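

No step can be read between compound 3 and compound 4, since each value is only a limit: the limit of < 20000 nM in this assay, at which 4 of the 4 values shown sit. The compounds shown leave open how strongly any of them inhibits in this assay, and whether (2-aminoethoxy)methyl in place of methoxy changes that.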